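Methyl Next to the Ring Nitrogen of Compound 3

The source may report more compounds than this note shows. Statements on the series, on what has been measured and on what is new or still open speak of the compounds shown alone.

Compound 1 `CN(C)c1ccc(C(=O)N[C@H]2CCC[C@H](NC(=O)c3cccc(Cl)c3)C2)cc1` gives 473 nM in a functional assay on HEK293 cells for antagonist activity at metabotropic glutamate receptor 5 (Homo sapiens), read by FLIPR and calcium flux; on this read-out higher numbers stand for weaker inhibition and lower numbers for stronger inhibition. Compound 2 `O=C(Cc1ccccn1)N[C@H]1CCC[C@H](NC(=O)c2cccc(Cl)c2)C1` shows only a limit of this assay, > 10000 nM. Compound 3 `O=C(N[C@H]1CCC[C@H](NC(=O)c2ccccn2)C1)c1cccc(Cl)c1` likewise shows only a limit, > 10000 nM. Both steps away from compound 1 are large: an at least 21-fold higher number from compound 1 to compound 2 (1.32 log units; beyond the scatter) and an at least 21-fold higher number from compound 1 to compound 3 (1.32 log units; beyond the scatter). The step that the two limits leave unreadable from compound 2 to compound 3 cannot be sized because of the limit of > 10000 nM in this assay, at which 2 of the 3 values shown sit. So compound 3 stands at the edge of what this assay reports, with one other value sitting at the same limit.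

Compound 4 `Cc1cccc(C(=O)N[C@H]2CCC[C@H](NC(=O)c3cccc(Cl)c3)C2)n1` differs from compound 3 by methyl in place of hydrogen on an aromatic carbon, on an aromatic carbon next to the ring nitrogen. Going by the values given here, no measured step tests such a methyl here. Compound 4 is therefore expected to stay near that limit, estimated at 10000 nM in this assay, between 3000 nM and 30000 nM. The expected step is a number no higher from compound 3 to compound 4 (the limit leaves the size open).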

Compound 4, half-maximal inhibitory concentration: 290 nM
Compound 4: middle estimate off by 34-fold (1.54 log units), on the high side; measured number outside the range, below it.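

A single methyl on the aromatic carbon next to the ring nitrogen is enough to turn a pyridin-2-yl compound sitting at a limit into a measurable inhibitor, an at least 34-fold lower number from compound 3 to compound 4 (1.53 log units; beyond the scatter). The 6-methylpyridin-2-yl group also separates clearly from the (pyridin-2-yl)methyl group, an at least 34-fold lower number from compound 2 to compound 4 (1.53 log units; beyond the scatter), and it stands level with the 4-(dimethylamino)phenyl group, a 1.6-fold lower number from compound 1 to compound 4 (0.21 log units; within the scatter). The first two steps start from a limit, not from a number, so their true size stays open: the limit of > 10000 nM in this assay, at which 2 of the 4 values shown sit.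

Going by these compounds, whether methyl itself matters here remains open: an ethyl, a methoxy or a chlorine on this carbon could do the same, less or more. So does the effect of a methyl on the other carbons of this ring.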